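The compounds below may be only part of what the source reports. "The series", "measured", "known", "first", "only" and "open" are said of these compounds alone.

Series notes. Of the compounds shown here, three of the shared core have been measured in an assay on Sf9 cells for inhibition of protein deacetylase HDAC6 (Homo sapiens), read by fluorescence, with a stated time of 40 min; on this read-out lower numbers stand for stronger inhibition and higher numbers for weaker inhibition. Compound 2 `O=C(NO)c1ccc(NCc2nc(-c3cccc(Cl)c3)nn2-c2ccccc2)cc1` gives 115 nM and stands lowest of the three. Compound 1 `Cc1ccc(-n2nc(-c3ccccc3)nc2CNc2ccc(C(=O)NO)cc2)cc1` gives 310 nM, and compound 3 `Cc1cccc(-n2nc(-c3ccccc3)nc2CNc2ccc(C(=O)NO)cc2)c1` gives 388 nM; from compound 1 to compound 3 the step is a 1.3-fold higher number from compound 1 to compound 3 (0.10 log units; within the scatter), so swapping the position of the methyl on the aryl carried by the ring nitrogen changes little. The gap from compound 2 to compound 1 and to compound 3 lies beyond the scatter.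

Compound 4 `Cc1ccsc1-c1nc(CNc2ccc(C(=O)NO)cc2)n(-c2ccccc2)n1` differs from compound 2 by 3-methylthiophen-2-yl in place of 3-chlorophenyl on an aromatic carbon. Going by the values given here, no measured step touches this position on the aromatic carbon between the two ring nitrogens; the only measured step concerns the aryl on the ring nitrogen and was within the scatter. On this basis the expected step from compound 2 to compound 4 in this assay is a 1.3-fold higher number from compound 2 to compound 4 (0.12 log units; within the scatter), with no change beyond the scatter expected but wide uncertainty. Compound 4 is therefore estimated at 150 nM, with a range from 50 nM to 450 nM.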

Compound 4, half-maximal inhibitory concentration: 30.7 nM
Beside the measured number, compound 4's estimate is 4.9-fold (0.69 log units) above it, outside the stated range (below it).
By their numbers in this assay, from the lowest: compound 4; then compound 2; then compounds 1 and 3 (each within the scatter of the next).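

In this assay, the aromatic carbon between two ring nitrogen atoms proves sensitive to the group it carries: 3-methylthiophen-2-yl in place of 3-chlorophenyl gives a 3.7-fold lower number from compound 2 to compound 4 (0.57 log units; beyond the scatter). Going by these compounds alone, the only earlier step concerned the aryl on the ring nitrogen and stayed within the scatter, so this is the first change to go beyond it, and it shows that a five-membered aromatic ring with 1 hetero atom is accepted at this position. Nothing at hand accounts for the size of this step.

The compounds shown leave open whether the lower number belongs to the thiophene ring or to its methyl, a question that plain thiophen-2-yl would address. Also open, as far as these compounds go, is how this position responds to a smaller, non-aromatic group such as an amine or a carboxylic acid.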